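The source may hold more compounds than are shown below. What is called first, only, known or untested is meant among the compounds shown, and "the series" means these compounds.

Working notes on the series. Three compounds of the shared core have numbers in a functional assay on MCF7 cells (Homo sapiens) for cytotoxicity, read by sulforhodamine B assay, with a stated time of 48 h; on this read-out higher numbers stand for weaker inhibition of growth and lower numbers for stronger inhibition of growth. Compound 1 `COc1ccc(/C(Cl)=C/C=C(\C#N)C(=O)c2c[nH]c3ccc(Br)cc23)cc1` gives 80300 nM, compound 2 `COc1ccc(/C(Cl)=C/C=C(\C#N)C(=O)c2c[nH]c3ccccc23)cc1` gives 47300 nM, and compound 3 `COc1ccc(/C(Cl)=C/C=C(\C#N)C(=O)c2c[nH]c3ccc(OC)cc23)cc1` gives 87100 nM. Compound 1 stands second highest of the three; its nearest neighbour is compound 3, with a 1.1-fold higher number from compound 1 to compound 3 (0.04 log units; within the scatter), and its furthest is compound 2, with a 1.7-fold lower number from compound 1 to compound 2 (0.23 log units; within the scatter). Neither of these steps leaves the scatter, nor does a 1.8-fold higher number from compound 2 to compound 3 (0.27 log units; within the scatter).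

The next compound, compound 4 `COc1ccc(/C(Cl)=C/C=C(\C#N)C(=O)c2c[nH]c3ccc(Br)cc23)cc1OC`, differs from compound 1 by methoxy in place of hydrogen on an aromatic carbon. Within the data shown here, the only measured step with the same kind of change, methoxy in place of hydrogen on an aromatic carbon, is the one from compound 2 to compound 3, which sits on the other ring and is within the scatter. Among the measured compounds shown here, no step on the ring that carries the change has been measured. On this basis the expected step in this assay from compound 1 to compound 4 is a 1.0-fold lower number from compound 1 to compound 4 (0.00 log units; within the scatter), none beyond the scatter. The estimate for compound 4 in this assay is therefore 80000 nM, with a range from 40000 nM to 160000 nM.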

Compound 4, concentration for 50% growth inhibition: 31900 nM
Compound 4: middle estimate off by 2.5-fold (0.40 log units), on the high side, outside the stated range (below it).
By their numbers in this assay, from the lowest: compounds 4, 2, 1 and 3 (each within the scatter of the next, the first and the last beyond it).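

In this assay, among these compounds, methoxy in place of hydrogen on the aromatic carbon ortho to a methoxy group and meta to a large group gives the first step beyond the scatter, a 2.5-fold lower number from compound 1 to compound 4 (0.40 log units; beyond the scatter). Sensitivity to substitution therefore appears at this position, whereas none of the steps among compounds 1, 2 and 3 left the scatter. The same replacement cannot be carried from one place to the other as a single expected step: the same change on two cores in this assay, a 1.8-fold higher number (0.27 log units; within the scatter) from compound 2 to compound 3 and a 2.5-fold lower number (0.40 log units; beyond the scatter) from compound 1 to compound 4, 4.6-fold (0.67 log units) apart, beyond the scatter of two such steps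

The compounds shown leave open whether this step depends on the bromo group of compound 1 or would also appear on the core of compound 2. They also leave open whether it is particular to methoxy or would be shared by a hydroxy group, an ethoxy group or an amine on the same carbon.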